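From thiophen-3-yl to 4-ethoxyphenyl

A few compounds are considered here, and "the series" means these few. Any claim that something is new, unique, unknown or untested is made for them only; others in the source may bear on it.

In a functional assay on FM3A cells (Mus musculus) for antiproliferative activity (a lower number here means a stronger inhibitor, a higher number a weaker inhibitor), compound 3 `COc1cc(C(=O)c2sc(-c3ccsc3)cc2N)cc(OC)c1OC` gives 3.7 nM, the lowest of the three measured numbers. Compound 1 `COc1ccc(-c2cc(N)c(C(=O)c3cc(OC)c(OC)c(OC)c3)s2)cc1OC`, which carries 3,4-dimethoxyphenyl, gives 72 nM, and compound 2 `COc1cc(C(=O)c2sc(-c3ccncc3)cc2N)cc(OC)c1OC`, which carries pyridin-4-yl, gives 150 nM. Compound 4 `CCOc1ccc(-c2cc(N)c(C(=O)c3cc(OC)c(OC)c(OC)c3)s2)cc1` has not yet been measured. It carries 4-ethoxyphenyl in place of thiophen-3-yl on an aromatic carbon.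

Going by the values given here, the closest precedent runs the opposite way, with thiophen-3-yl replacing 3,4-dimethoxyphenyl, and gave a 19-fold lower number from compound 1 to compound 3 (1.29 log units; beyond the scatter). Thiophen-3-yl replacing pyridin-4-yl gave a 41-fold lower number from compound 2 to compound 3 (1.61 log units; beyond the scatter), so the group at this place can move this assay widely. Leaving thiophen-3-yl is thus expected to raise the number. No measurement compares 4-ethoxyphenyl with 3,4-dimethoxyphenyl directly, so the size of the rise remains uncertain, and it may fall short of the full gap to compound 1 at 72 nM. The expected change is a 3.2-fold higher number from compound 3 to compound 4 (0.51 log units; beyond the scatter). For compound 4 the estimate is 12 nM, with an expected range from 2 nM to 70 nM.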

Compound 4, half-maximal inhibitory concentration: 510 nM
Compound 4: middle estimate off by 43-fold (1.63 log units), on the low side; measured number outside the range, above it.
By their numbers in this assay, from the lowest: compound 3; then compound 1; then compound 2; then compound 4.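

In this assay, going by these compounds alone, the step from thiophen-3-yl to 4-ethoxyphenyl (a 140-fold higher number from compound 3 to compound 4 (2.14 log units; beyond the scatter)) is the widest yet seen at this place on the shared core, exceeding every step among the earlier compounds. It also shows that a phenyl ring here does not fix the number: the ring with 4-ethoxyphenyl stands apart from 3,4-dimethoxyphenyl (a 7.1-fold higher number from compound 1 to compound 4 (0.85 log units; beyond the scatter)), and it also falls behind pyridin-4-yl (a 3.4-fold higher number from compound 2 to compound 4 (0.53 log units; beyond the scatter)), making compound 4 the weakest of the four. Nothing available explains these differences.

As far as these compounds go, it remains open whether the rise follows the ethyl chain itself, as 4-methoxyphenyl or an unsubstituted phenyl would help to tell. From the compounds shown here alone, it is equally open whether other five-membered rings, such as thiophen-2-yl or furan-3-yl, would stay close to compound 3.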